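The source may report more compounds than this note shows. Statements on the series, on what has been measured and on what is new or still open speak of the compounds shown alone.

Compound 1 `CC1(CN)CCN(c2c(F)cc3c(=O)c(C(=O)O)cn(C4CC4)c3c2F)C1`: 8 ug/mL
Compound 2 `CC1(CN)CCN(c2c(F)cc3c(=O)c(C(=O)O)cn(C4CC4)c3c2Cl)C1`: 8 ug/mL

In a functional assay on V79 cells (Cricetulus griseus) for cytotoxicity, read by colony formation (a lower number here means a stronger inhibitor, a higher number a weaker inhibitor), compound 2 gives 8 ug/mL, level with compound 1 at 8 ug/mL. Compound 3 `CC1(CN)CCN(c2c(F)cc3c(=O)c(C(=O)O)cn(C4CC4)c3c2C(F)(F)F)C1` differs from compound 2 in one place, with trifluoromethyl in place of chloro on an aromatic carbon. That carbon is ortho to a 3-(aminomethyl)-3-methylpyrrolidin-1-yl group and meta to a fluoro group. Within the data shown here, one measured step bears on this change: no change at the digits printed from compound 1 to compound 2 (within the scatter), with chloro in place of fluoro on the same aromatic carbon. Among the measured compounds shown here, it is a single step, and no measured compound carries trifluoromethyl, so the size of this change remains open. No shift beyond the scatter is therefore expected, and the expected change is a 1.3-fold higher number from compound 2 to compound 3 (0.10 log units; within the scatter). The estimated value for compound 3 is 10 ug/mL, with an expected range of 4 ug/mL to 30 ug/mL.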

Compound 3, half-maximal inhibitory concentration: 110 ug/mL
Estimate against measurement, compound 3: 11-fold (1.04 log units) below; the whole stated range lies below it.
By their numbers in this assay, from the lowest: compounds 1 and 2 (each within the scatter of the next); then compound 3.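

In this assay, this aromatic carbon, ortho to the 3-(aminomethyl)-3-methylpyrrolidin-1-yl group, proves sensitive to what it carries: trifluoromethyl in place of chloro gives a 14-fold higher number from compound 2 to compound 3 (1.14 log units; beyond the scatter), and trifluoromethyl in place of fluoro gives a 14-fold higher number from compound 1 to compound 3 (1.14 log units; beyond the scatter). The earlier pair showed only that fluoro and chloro stand level here, which said nothing about a group of four heavy atoms, and compound 3 now reads as the weakest inhibitor of the three. No measurement shown accounts for this jump.

The three compounds do not tell whether the jump is particular to trifluoromethyl or would also appear with methyl, methoxy or a nitrile on this carbon. Nor do they show whether it would persist with another amine in place of the 3-(aminomethyl)-3-methylpyrrolidin-1-yl group.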